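A few compounds are considered here, and "the series" means these few. Any claim that something is new, unique, unknown or untested is made for them only; others in the source may bear on it.

Measured compounds in a functional assay (cardiac atrium) for agonist activity, with Cavia porcellus as the target; a higher number here means that more compound is needed for the effect, a lower number that less compound is needed:
- compound 1 `CCO/C(O)=C1\C(C)=NC(C)=C([N+](=O)[O-])C1c1ccncc1`: 6460 nM
- compound 2 `CC1=NC(C)=C([N+](=O)[O-])C(c2cccnc2)/C1=C(\O)OC1CCCCC1`: 2760 nM
- compound 3 `CC1=NC(C)=C([N+](=O)[O-])C(c2cccnc2)/C1=C(\O)OC1CCCC1`: 3280 nM

Among these three, compound 1 gives the highest number in this assay. Its gap to compound 3 is within the scatter, while its gap to compound 2 is beyond it; compounds 2 and 3 differ from compound 1 both in the ester group and in how the pyridine is attached, so their values alone do not separate those two differences.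

The step from compound 1 to compound 4 `CC1=NC(C)=C([N+](=O)[O-])C(c2ccncc2)/C1=C(\O)OCC(C)C` is isopropyl in place of methyl on a saturated chain carbon bound to an oxygen on an unsaturated carbon. Going by the values given here, the only measured step that changes the ester alkyl is the one from compound 2 to compound 3, cyclopentyl in place of cyclohexyl on an oxygen on an unsaturated carbon, which gave a 1.2-fold higher number from compound 2 to compound 3 (0.07 log units; within the scatter). That step bears on the present one only loosely, since neither of its ester groups is ethyl or isobutyl, but it shows that exchanging one saturated ester group for another of similar kind left the number essentially unchanged.

Compound 4 is therefore expected to stay close to compound 1 in this assay, with at most a modest drift toward a lower number; the estimated step is a 1.4-fold lower number from compound 1 to compound 4 (0.16 log units; within the scatter). The estimate for compound 4 is 4500 nM, with a range from 1500 nM to 13000 nM.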

Compound 4, half-maximal effective concentration: 8510 nM
Compound 4: the middle estimate sits 1.9-fold (0.28 log units) below what was measured; the measured number falls inside the stated range.
By their numbers in this assay, from the lowest: compounds 2, 3, 1 and 4 (each within the scatter of the next, the first and the last beyond it).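

In this assay, exchanging ethoxy for isobutoxy, that is, isopropyl in place of methyl on a saturated chain carbon bound to an oxygen on an unsaturated carbon, gives a 1.3-fold higher number from compound 1 to compound 4 (0.12 log units; within the scatter) and so stays within the scatter. Going by these compounds alone, this is the first direct reading of a change in the ester group on the core of compound 1, and it shows that the branched isobutyl group leaves the number unchanged within the scatter, as the exchange of cyclic groups did with a 1.2-fold higher number from compound 2 to compound 3 (0.07 log units; within the scatter) on the other pyridine attachment. No measurement at hand accounts for this result.

On these data alone, whether an ester group carrying an amine or a carboxylic acid, or a much longer chain, would stay as close to compound 1 in this assay remains open. As far as these compounds go, the separate weight of the ester group and of the way the pyridine is attached also remains open: compound 2 and compound 3 differ from compound 1 in both, and their numbers do not separate the two.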